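The source may report more compounds than this note shows. Statements on the series, on what has been measured and on what is new or still open speak of the compounds shown alone.

Measured in a functional assay with Oryctolagus cuniculus as the target; on this read-out lower numbers stand for stronger inhibition and higher numbers for weaker inhibition:
- compound 1 `COc1ccc(-c2nc(N=C(N)N)sc2-c2ccc(OC)cc2)cc1`: 31000 nM
- compound 2 `CNC(=N)Nc1nc(-c2ccc(OC)cc2)c(-c2ccc(OC)cc2)s1`: 62 nM
- compound 3 `COc1ccc(-c2nc(/N=C(\N)NC3CCCCC3)sc2-c2ccc(OC)cc2)cc1`: > 1000 nM, a limit and not a number

Compound 3 has only a limit on this read-out, and it stands at the limit of > 1000 nM in this assay, at which 1 of the 3 values shown sits.

Next comes compound 4 `COc1ccc(-c2nc(CN)sc2-c2ccc(OC)cc2)cc1`, with the change (a group of 2 heavy atoms (1 carbon, 1 nitrogen; no ring) in place of a group of 10 heavy atoms (7 carbon, 3 nitrogen; one six-membered non-aromatic ring of carbon only), on an aromatic carbon). Aminomethyl enters on an aromatic carbon of a five-membered aromatic ring with 1 nitrogen and 1 sulfur, and the group that enters has no ring.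

Among the compounds with values here, two measured steps bear on this change, both large and beyond the scatter: a 500-fold lower number from compound 1 to compound 2 (2.70 log units; beyond the scatter) and an at least 16-fold higher number from compound 2 to compound 3 (1.20 log units; beyond the scatter). The third, a step that the limit leaves unreadable from compound 1 to compound 3, cannot be read. Changes at this place can therefore move the number a long way in either direction. Only compound 2 reaches a low number, at 62 nM, and aminomethyl does not retain its group. A number on the weak side is therefore expected, with no step beyond the scatter firmly expected and no firm direction. The estimated step is a step that the limit leaves unreadable from compound 3 to compound 4. For compound 4 the expected value is 2000 nM, with an estimated range of 150 nM to 30000 nM.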

Compound 4, half-maximal inhibitory concentration: > 100 nM
Compound 4: only a limit was reported; the forecaster's own chance of this, stated with the estimate: 30%; the middle value does not contradict the limit.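

In this assay compound 4 gives > 100 nM as a limit and not a number. Within the data shown here, the one step that can be read is an at least 1.6-fold higher number from compound 2 to compound 4 (0.20 log units; that floor lies within the scatter) and its floor does not separate aminomethyl from the larger group of compound 2 at this aromatic carbon. This is the first compound shown with a single nitrogen in the group at this place, and its limit does not rule out a value close to that of compound 2, while the steps to compound 1 and compound 3 cannot be read.

Going by these compounds, whether compound 4 lies near compound 2 or far from it stays open. Also open, on these data alone, is how a longer chain such as aminoethyl, an amine set directly on the ring, or a carboxylic acid would read at this place.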